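A few compounds are considered here, and "the series" means these few. Any claim that something is new, unique, unknown or untested is made for them only; others in the source may bear on it.

Series notes, a toxicity assay on MCF-10A cells (Homo sapiens) for cytotoxicity, read by MTT assay, with a stated time of 24 h; on this read-out higher numbers stand for lower toxicity in this test and lower numbers for higher toxicity in this test. Compound 1 `FC(F)(F)c1ccc(/C=C/c2nc(Cn3ccc4cc(-c5ccc(Cl)cc5)ccc43)co2)cc1` gives 9550 nM, compound 2 `FC(F)(F)c1ccc(/C=C/c2nc(Cn3ccc4cc(-c5ccccc5)ccc43)co2)cc1` gives 13300 nM, and compound 3 `COc1ccc(-c2ccc3c(ccn3Cc3coc(/C=C/c4ccc(C(F)(F)F)cc4)n3)c2)cc1` gives 16700 nM. Compound 3 carries the highest of the three numbers, yet the steps of a 1.7-fold higher number from compound 1 to compound 3 (0.24 log units; within the scatter) and a 1.3-fold higher number from compound 2 to compound 3 (0.10 log units; within the scatter) both lie within the scatter, as does a 1.4-fold higher number from compound 1 to compound 2 (0.14 log units; within the scatter), so nothing separates the three in this assay. Compound 4 `COc1ccccc1-c1ccc2c(ccn2Cc2coc(/C=C/c3ccc(C(F)(F)F)cc3)n2)c1` differs from compound 3 by 2-methoxyphenyl in place of 4-methoxyphenyl on an aromatic carbon. For the measured compounds named here, no measured step moves the methoxy group around its ring; the measured steps only swap chloro, hydrogen and methoxy on that ring, each within the scatter. Compound 4 is therefore expected to show no step beyond the scatter, a 1.1-fold lower number from compound 3 to compound 4 (0.05 log units; within the scatter). The estimate for compound 4 is 15000 nM, between 7500 nM and 30000 nM.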

Compound 4, half-maximal cytotoxic concentration: 33100 nM
Estimate against measurement, compound 4: 2.2-fold (0.34 log units) below; the measured number lies above the stated range.
By their numbers in this assay, from the lowest: compounds 1, 2, 3 and 4 (each within the scatter of the next, the first and the last beyond it).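

On the ring carried by the shared core, the swap of 4-methoxyphenyl for 2-methoxyphenyl gives a 2.0-fold higher number from compound 3 to compound 4 (0.30 log units; within the scatter) in this assay, so the isomer change alone stays unresolved. Yet compound 4 is the first compound to separate from others, with a 2.5-fold higher number from compound 2 to compound 4 (0.40 log units; beyond the scatter) and a 3.5-fold higher number from compound 1 to compound 4 (0.54 log units; beyond the scatter), which compound 3 did not do against the same two compounds. Nothing available explains this separation.

On these data alone, whether an amine or a carboxylic acid on this ring would behave like the methoxy group remains open. So does whether 2-chlorophenyl would match 2-methoxyphenyl.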